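The source may hold more compounds than are shown below. What is called first, only, known or untested is meant among the compounds shown, and "the series" means these compounds.

Measured in a functional assay on NCI-H1975 cells (Homo sapiens) for antiproliferative activity, read by CellTiter-Glo, with a stated time of 96 h; on this read-out lower numbers stand for stronger inhibition and higher numbers for weaker inhibition:
- compound 1 `COc1ccc(-c2nsc3c2NC(=O)CC3c2cccc(OC)c2)cc1`: 1980 nM
- compound 2 `COc1ccc(-c2nsc3c2NC(=O)CC3c2ccc3c(c2)OCCO3)cc1`: 1240 nM

On these numbers, compound 1 at 1980 nM stands within the scatter of compound 2 at 1240 nM, so the two cannot be separated. Compound 3 `COc1ccc(-c2nsc3c2NC(=O)CC3c2ccsc2)cc1`, not yet measured, has thiophen-3-yl in place of 3-methoxyphenyl on a saturated ring carbon. For the measured compounds named here, no measured pair differs in one place, so the size of this change rests on expectation alone. In this assay the expected step of a 1.0-fold higher number from compound 1 to compound 3 (0.00 log units; within the scatter) is estimated to stay within the scatter, in neither direction. Compound 3 is expected to give 2000 nM, with an estimated range of 900 nM to 4500 nM.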

Compound 3, half-maximal inhibitory concentration: 254 nM
Beside the measured number, compound 3's estimate is 7.9-fold (0.90 log units) above it; measured number below the stated range.
By their numbers in this assay, from the lowest: compound 3; then compounds 2 and 1 (each within the scatter of the next).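

In this assay, the saturated ring carbon three ring bonds from the ring nitrogen proves sensitive to the ring it carries: thiophen-3-yl in place of 3-methoxyphenyl gives a 7.8-fold lower number from compound 1 to compound 3 (0.89 log units; beyond the scatter) on an otherwise unchanged core. Nothing measured here explains this step.

From the compounds shown here alone, it remains open whether the sulfur atom or the five-membered ring accounts for the step. Going by these compounds, how furan-3-yl, pyridin-3-yl or a saturated cyclopentyl group would fare at this position also remains open.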